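The compounds below may be only part of what the source reports. "The series", "measured", "known", "first", "only" and "open" are said of these compounds alone.

In a functional assay on the whole organism (Tail, strain ICR) with Mus musculus as the target, in the tail flick test, with a stated time of 30 min, at a dose of 6.25 umol/kg by the oral route (on this read-out lower numbers stand for a weaker effect and higher numbers for a stronger effect at the one dose given), compound 1 `O=C(CN(c1nc(Cl)nc2[nH]cnc12)C1CC1)NCC(=O)OCc1ccccc1` gives 5.73%. Compound 2 `CC(C)[C@H](NC(=O)CN(c1nc(Cl)nc2[nH]cnc12)C1CC1)C(=O)OCc1ccccc1` gives 7.69% in this assay. Within the data shown here, the one measured step, a number 2 percentage points higher from compound 1 to compound 2 (within the scatter), is within the scatter, so compound 2 stands level with compound 1 rather than above it. Compound 3 `NCCCC[C@H](NC(=O)CN(c1nc(Cl)nc2[nH]cnc12)C1CC1)C(=O)OCc1ccccc1` differs from compound 2 by 4-aminobutyl in place of isopropyl on a saturated chain carbon bound to an amide-type nitrogen and a carbonyl carbon. Among the measured compounds shown here, only that single step touches the same place, and no measured step brings in a 4-aminobutyl group, so the change is expected to be small: a number 0.3 percentage points higher from compound 2 to compound 3 (within the scatter). Compound 3 is therefore estimated at 8%, with a range from 0% to 22%.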

Compound 3, a percentage reported as activity, at one dose (the size of the read-out at that dose, not a potency): 9.19%
Beside the measured number, compound 3's estimate is 1.2 percentage points below it; the range from low to high includes it.
By their numbers in this assay, from the lowest: compounds 1, 2 and 3 (each within the scatter of the next).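

In this assay this position now carries a chain with a nitrogen in it, 4-aminobutyl in place of isopropyl, yet the two compounds stand level (a number 1.5 percentage points higher from compound 2 to compound 3 (within the scatter)). Set against plain hydrogen at the same place, the longer chain also stays within the scatter (a number 3.5 percentage points higher from compound 1 to compound 3 (within the scatter)). So on this saturated chain carbon, neither side chain separates from hydrogen at this dose, and no supporting data explain the result. From the compounds shown here alone, whether a carboxylic acid or a benzyl group at this place would read differently stays open. Also open, going by these compounds, is whether a change elsewhere, such as to the benzyl ester, would matter more.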